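The compounds below may be only part of what the source reports. "The series", "measured", "known", "first", "only" and "open" are said of these compounds alone.

Measured in this study:
compound 1 `CC(C)NC(=N)c1ccc2oc(-c3cccc(OCCCOc4ccccc4)c3)cc2c1`: 26500 nM
compound 2 `c1ccc(OCCCCCOc2cccc(-c3cc4cc(C5=NCCN5)ccc4o3)c2)cc1`: 2600 nM
compound 3 `N=C(N)c1ccc2cc(-c3ccc(OCCCOc4ccccc4)cc3)oc2c1`: 8600 nM

In an ADME assay on L6 cells (Rattus norvegicus) for cytotoxicity, read by resazurin assay, with a stated time of 70 h (a higher number here means a weaker inhibitor, a lower number a stronger inhibitor), compound 3 holds the second highest of the three numbers; compound 1 stands beyond the scatter above it, and compound 2 beyond the scatter below it. Compound 4 `c1ccc(OCCCOc2ccc(-c3cc4ccc(C5=NCCN5)cc4o3)cc2)cc1` has not been measured. It differs from compound 3 by a group of 5 heavy atoms (3 carbon, 2 nitrogen; one five-membered non-aromatic ring with 2 hetero atoms) in place of a group of 3 heavy atoms (1 carbon, 2 nitrogen; no ring), on an aromatic carbon. Among the measured compounds shown here, no measured pair follows the same change; compound 2 carries the same ring but on a different chain, so its number cannot settle the step on its own. A modest step downward, but not far beyond the scatter, is expected: a 1.7-fold lower number from compound 3 to compound 4 (0.24 log units; within the scatter). Compound 4 is therefore estimated at 5000 nM, with a range from 1500 nM to 15000 nM.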

Compound 4, half-maximal inhibitory concentration: 16800 nM
The estimate for compound 4 lay 3.4-fold (0.53 log units) below the measured number, outside the stated range (above it).
By their numbers in this assay, from the lowest: compound 2; then compounds 3, 4 and 1 (each within the scatter of the next, the first and the last beyond it).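

In this assay, among the compounds shown here, the five-membered non-aromatic ring with 2 hetero atoms, taking the place of the group with no ring on this aromatic carbon, gives a 2.0-fold higher number from compound 3 to compound 4 (0.29 log units; within the scatter), the first step that isolates this change. Within the scatter, the two groups cannot be told apart at this position. No available evidence explains the step. 

The compounds shown leave open whether an amine or a carboxylic acid on the same carbon would separate from these two groups. They also leave open whether this change would read the same with a longer chain.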